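Bromo in Place of Chloro on Two Different Cores

This account rests on a few compounds, and the source may have more. Where it says the series, first, only, none or still open, it means among the compounds named here.

In a functional assay on Jurkat cells (Homo sapiens) for cytotoxicity, read by luminescence and CellTiter-Glo, with a stated time of 3 days (on this read-out higher numbers stand for weaker inhibition and lower numbers for stronger inhibition), three compounds have been measured:

Compound 1, `O=C(Nc1ccc(C(F)(F)F)cc1)c1ccc(Cl)cc1O`, gives 670 nM.
Compound 2, `O=C(Nc1ccc(C(F)(F)F)cc1)c1ccc(Br)cc1O`, gives 500 nM.
Compound 3, `O=C(Nc1ccc(Cl)c(Cl)c1)c1cc(F)ccc1O`, gives 670 nM.

Compound 2 differs from compound 1 in one place, (bromo in place of chloro on an aromatic carbon). The step in this assay is a 1.3-fold lower number from compound 1 to compound 2 (0.13 log units; within the scatter), so the two numbers lie within the scatter of each other and nothing can be said about their order. Compound 3 is built on a different core from compound 1; how the two cores differ is not broken down here. In this assay compound 3 and compound 1 stand level at the digits given, and compound 3 differs from compound 2 only within the scatter.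

Compound 4, `O=C(Nc1ccc(Br)c(Cl)c1)c1cc(F)ccc1O`, has not yet been measured. It differs from compound 3 by bromo in place of chloro on an aromatic carbon. This is the same kind of change as that from compound 1 to compound 2, but not the same: in compound 1 the exchanged halogen sits meta to a hydroxy group, whereas in compound 3 it sits ortho to a chloro group; in both it is para to a large group.

Resting on the step of a 1.3-fold lower number from compound 1 to compound 2 (0.13 log units; within the scatter), which lies within the scatter, the step from compound 3 to compound 4 in this assay is expected to be a 1.3-fold lower number from compound 3 to compound 4 (0.13 log units; within the scatter). Compound 4 is therefore estimated at 500 nM, with a range from 250 nM to 1000 nM.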

Compound 4, half-maximal inhibitory concentration: 860 nM
Estimate against measurement, compound 4: 1.7-fold (0.24 log units) below, within the range that was stated.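

In this assay, putting bromo in place of chloro on the core of compound 3, on an aromatic carbon ortho to a chloro group and para to a large group, gives a 1.3-fold higher number from compound 3 to compound 4 (0.11 log units; within the scatter), so compound 3 and compound 4 cannot be put in order. Set beside the same exchange on the core of compound 1, the two steps compare as follows: the same change on two cores in this assay, a 1.3-fold lower number (0.13 log units; within the scatter) from compound 1 to compound 2 and a 1.3-fold higher number (0.11 log units; within the scatter) from compound 3 to compound 4, 1.7-fold (0.24 log units) apart, within the scatter of two such steps. On these two pairs, then, the exchange carries from one core to the other without any difference that can be told apart from the scatter, but neither step can be read as a gain or a loss, the opposite directions of the printed numbers carry no meaning, and two pairs on two cores make no rule for the series or for other places on these rings.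

The compounds shown leave open what this place tolerates beyond halogens, for example an amine, a carboxylic acid, a methoxy group or a longer chain, any of which might move the number in this assay by more than the scatter. They also leave open whether the hydroxy group and the amide that all four compounds share can be replaced, for instance by a methoxy group or a reversed amide, and how such a replacement would read in this cytotoxicity measurement.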